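A few compounds are considered here, and "the series" means these few. Any claim that something is new, unique, unknown or untested is made for them only; others in the source may bear on it.

Compound 1 `CCN1CCN(C(=S)SCC(O)Cn2c([N+](=O)[O-])cnc2C)CC1` gives in a toxicity assay on HeLa cells (Homo sapiens) for cytotoxicity, read by MTT assay, with a stated time of 24 h (a higher number here means a weaker inhibitor, a lower number a stronger inhibitor), only a limit, > 5000000 nM.
Compound 2 `Cc1ncc([N+](=O)[O-])n1CC(O)CSC(=S)N1CCN(c2ccccn2)CC1` gives in this assay 2970000 nM.
Compound 3 `Cc1ncc([N+](=O)[O-])n1CC(O)CSC(=S)N1CCCC1` gives in this assay 1340000 nM.

Among the two numbers, compound 3 stands lowest, and compound 2 gives the nearest number. Compound 4 `Cc1ncc([N+](=O)[O-])n1CC(O)CSC(=S)N1CCOCC1` differs from compound 3 by morpholin-4-yl in place of pyrrolidin-1-yl on a thiocarbonyl carbon. For the measured compounds named here, two measured steps bear on this. an at least 3.7-fold lower number from compound 1 to compound 3 (0.57 log units; beyond the scatter) changed the amine on the thiocarbonyl carbon and is at least modest, whereas an at least 1.6-fold lower number from compound 1 to compound 2 (0.22 log units; that floor lies within the scatter) altered only the group on the piperazine nitrogen and stayed within the scatter. The change to compound 4 again alters the amine on the thiocarbonyl carbon. The step from compound 3 to compound 4 is therefore expected to be modest, estimated at a 1.5-fold higher number from compound 3 to compound 4 (0.17 log units; within the scatter), more likely towards a higher number. Compound 4 is expected to give about 2000000 nM, within 700000 nM to 6000000 nM.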

Compound 4, half-maximal inhibitory concentration: 4520000 nM
The estimate for compound 4 lay 2.3-fold (0.35 log units) below the measured number; the range from low to high includes it.
By their numbers in this assay, from the lowest: compound 3; then compounds 2 and 4 (each within the scatter of the next). At a limit, above all of these: compound 1.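

At the thiocarbonyl carbon, this assay now gives a step between two actual numbers rather than one from a limit: a 3.4-fold higher number from compound 3 to compound 4 (0.53 log units; beyond the scatter), with morpholin-4-yl in place of pyrrolidin-1-yl. The other new step, an at least 1.1-fold lower number from compound 1 to compound 4 (0.04 log units; that floor lies within the scatter), has a floor within the scatter, and its true size cannot be read because compound 1 stands at a limit: the limit of > 5000000 nM in this assay, at which 1 of the 4 values shown sits.

The compounds shown leave open whether the higher number goes with the ring oxygen or with the six-membered ring, which a piperidin-1-yl group would separate. As far as these compounds go, how an open-chain amine such as diethylamino would stand at this carbon also remains open.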